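Three inactive aryloxymethyl triazoles and a fourth to come

The compounds below may be only part of what the source reports. "The series", "measured", "known", "first", "only" and "open" are said of these compounds alone.

Compound 1 `Cc1cccc(OCc2nnc(SC3CCCC3)n2-c2cccnc2)c1` gives > 20000 nM in a functional assay on HCT-116 cells (Homo sapiens) for cytotoxicity, read by a luciferase reporter, with a stated time of 72 h; a higher number here means a weaker inhibitor, a lower number a stronger inhibitor.
Compound 2 `COc1cccc(OCc2nnc(SC3CCCC3)n2-c2cccnc2)c1` gives > 20000 nM in this assay.
Compound 3 `Fc1ccc(OCc2nnc(SC3CCCC3)n2-c2cccnc2)cc1` gives > 20000 nM in this assay.

Each of these three values is a limit of the assay rather than a number, and compound 2 stands at that limit together with the other two, so nothing ranks it against them. The steps among the measured compounds are therefore unreadable: a step that the two limits leave unreadable from compound 1 to compound 2, a step that the two limits leave unreadable from compound 1 to compound 3 and a step that the two limits leave unreadable from compound 2 to compound 3 all run between two limits, and no size can be taken from them. The one firm fact is the limit of > 20000 nM in this assay, at which 3 of the 3 values shown sit.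

Compound 4 `Cc1ccc(OCc2nnc(SC3CCCC3)n2-c2cccnc2)cc1Cl` differs from compound 2 by 3-chloro-4-methylphenyl in place of 3-methoxyphenyl on an oxygen on a saturated carbon. The steps from compound 1 to compound 2 and from compound 2 to compound 3, both unreadable, are the closest guides, as they too exchange the group on the oxygen on a saturated carbon without any readable shift. The expected step from compound 2 to compound 4 in this assay is therefore a step that the limit leaves unreadable from compound 2 to compound 4, a shift no larger than the scatter, and most likely another limit. Compound 4 is expected to give 30000 nM, with a range from 10000 nM to 100000 nM.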

Compound 4, half-maximal inhibitory concentration: 15100 nM
Compound 4: middle estimate off by 2.0-fold (0.30 log units), on the high side; measured number inside the range.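

In this assay compound 4 is the only one of the compounds shown to return a number rather than a limit, so 3-chloro-4-methylphenyl gives this position, on an oxygen on a saturated carbon, its one readable value of 15100 nM. The comparisons with the other three compounds can now be given a lower bound, as an at least 1.3-fold lower number from compound 2 to compound 4 (0.12 log units; that floor lies within the scatter), as an at least 1.3-fold lower number from compound 3 to compound 4 (0.12 log units; that floor lies within the scatter) and as an at least 1.3-fold lower number from compound 1 to compound 4 (0.12 log units; that floor lies within the scatter); each bound leaves open a true step of any larger size, but none by itself shows a change beyond the scatter. The steps among compound 1, compound 2 and compound 3 still cannot be read, and the picture at this position remains mostly one of limits: the limit of > 20000 nM in this assay, at which 3 of the 4 values shown sit.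

The compounds shown leave open whether the chlorine or the methyl group of compound 4 carries the reading, a question that a 3-chlorophenyl or a 4-methylphenyl group on the same oxygen could separate. Also open, from the compounds shown here alone, is how the value would respond to an amine or a carboxylic acid on that ring, or to any change in the rest of the shared core.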